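From 4-fluorobenzyl to 3-fluorobenzyl: working notes

This account rests on a few compounds, and the source may have more. Where it says the series, first, only, none or still open, it means among the compounds named here.

compound 1 `N#C/C(=C\c1ccccc1OS(=O)(=O)c1ccccc1[N+](=O)[O-])C(=O)Nc1nnc(Cc2ccc(F)cc2)s1` gives 6%
compound 2 `N#C/C(=C\c1ccccc1OS(=O)(=O)c1ccc(F)cc1)C(=O)Nc1nnc(Cc2ccc(F)cc2)s1` gives "not toxic" (no number reported)

Within the data shown here, in an ADME assay on HEK-293T cells (Homo sapiens) for inhibition, read by CCK-8 assay, with a stated time of 48 h, tested at 20 uM (a higher number here means more inhibition of growth at the concentration tested, a lower number less inhibition of growth), compound 1 gives 6% and stands alone as the only number. Compound 2 has a verdict but no number, so compound 1 cannot be ranked against it.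

Compound 3 `N#C/C(=C\c1ccccc1OS(=O)(=O)c1ccccc1[N+](=O)[O-])C(=O)Nc1nnc(Cc2cccc(F)c2)s1` keeps the core of compound 1 and changes a single group. The whole difference is 3-fluorophenyl in place of 4-fluorophenyl on a saturated chain carbon bound to an aromatic carbon and amounts to 3-fluorophenyl in place of 4-fluorophenyl on a saturated chain carbon bound to an aromatic carbon. Among the measured compounds shown here, no measured pair shows what this change does, so no step beyond the scatter is expected in this assay and neither direction is favoured. The expected step of a number 1 percentage points higher from compound 1 to compound 3 (within the scatter) is estimated to be small. This expectation rests on compound 1 at 6% alone, so the margin is kept generous. For compound 3 the expected value is 7% with an estimated range from 0% to 20% in this measurement.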

Compound 3, percent growth inhibition at one concentration: "not toxic" (no number reported)
Compound 3: no number reported; there is nothing to compare the estimate with.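

Among these compounds, compound 3 carries the verdict "not toxic" without a number in this assay, so no step from compound 1, at 6%, can be read. What the compounds shown leave open is whether 3-fluorobenzyl in place of 4-fluorobenzyl shifts growth inhibition at all. Nothing shown bears on this result.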